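A few compounds are considered here, and "the series" means these few. Any claim that something is new, unique, unknown or untested is made for them only; others in the source may bear on it.

Among the compounds with values here, compound 2, `O=C(NC(=S)NNc1ncnc2ccccc12)c1cccc(Cl)c1`, carries the lowest of the two numbers measured so far in a functional assay on GLC82 cells (Homo sapiens) for cytotoxicity, read by MTT assay, with a stated time of 72 h; on this read-out higher numbers stand for weaker inhibition and lower numbers for stronger inhibition: compound 2 gives 3240 nM, while its nearest neighbour, compound 1, `O=C(NC(=S)NNc1ncnc2ccccc12)c1ccccc1`, gives 8370 nM. Within the data shown here, the single step between them, a 2.6-fold lower number from compound 1 to compound 2 (0.41 log units; beyond the scatter), is the only measured change in this small set, and it is modest though beyond the scatter. Compound 3, `O=C(NC(=S)NNc1ncnc2ccccc12)c1ccccc1Cl`, keeps every atom of compound 2 but arranges them differently: 2-chlorophenyl in place of 3-chlorophenyl on a carbonyl carbon. Among the measured compounds shown here, no measured step compares two positions of chlorine on this ring. For the measured compounds named here, the one step that bears on the change, a 2.6-fold lower number from compound 1 to compound 2 (0.41 log units; beyond the scatter), shows only that a chlorine on the ring brings a modest gain over an unsubstituted ring, and it says nothing about whether the place of the chlorine matters. Compound 3 is therefore expected to stay close to compound 2 in this assay, with an expected step of a 1.2-fold higher number from compound 2 to compound 3 (0.09 log units; within the scatter) that need not exceed the scatter. For compound 3 the estimated value is 4000 nM, within a range of 1500 nM to 11000 nM.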

Compound 3, half-maximal inhibitory concentration: 10800 nM
Estimate against measurement, compound 3: 2.7-fold (0.43 log units) below, within the range that was stated.
By their numbers in this assay, from the lowest: compound 2; then compounds 1 and 3 (each within the scatter of the next).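

Moving the chlorine shows that its place on the ring counts in this assay: the change to 2-chlorophenyl on the carbonyl carbon gives a 3.3-fold higher number from compound 2 to compound 3 (0.52 log units; beyond the scatter), a modest step, whereas the earlier compounds offered only a comparison of a chlorine with a hydrogen. The gain seen earlier, a 2.6-fold lower number from compound 1 to compound 2 (0.41 log units; beyond the scatter), therefore does not belong to a chlorine on this ring as such, since the other placement gives a 1.3-fold higher number from compound 1 to compound 3 (0.11 log units; within the scatter), and so the 2-chlorophenyl compound cannot be told apart from the unsubstituted one; of the two chlorine placements shown, only 3-chlorophenyl stands apart from the plain phenyl ring. Nothing available here explains why the two placements differ.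

The compounds shown rest on a single substituent, so they leave open whether the same dependence on place would hold for a fluoro or methoxy group, or for an amine, in the chlorine's stead. They also leave open whether a second chlorine on the ring, or a change elsewhere on the shared core, would move the numbers further than these modest steps.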